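Ethoxycarbonyl to acetyl on two differently linked cores

A few compounds are considered here, and "the series" means these few. Any claim that something is new, unique, unknown or untested is made for them only; others in the source may bear on it.

Measured compounds:
compound 1, `C=C(C)[C@@H]1CC=C(Cn2cc(COc3cccc(C4NC(=O)NC(C)=C4C(=O)OCC)c3)nn2)CC1`: 12200 nM
compound 2, `C=C(C)[C@@H]1CC=C(Cn2cc(COc3ccccc3C3NC(=O)NC(C)=C3C(=O)OCC)nn2)CC1`: > 100000 nM
compound 3, `C=C(C)[C@@H]1CC=C(Cn2cc(COc3cccc(C4NC(=O)NC(C)=C4C(C)=O)c3)nn2)CC1`: 30500 nM

The three measured compounds were tested in a functional assay on U-251 cells (Homo sapiens) for inhibition, read by sulforhodamine B assay, with a stated time of 48 h; on this read-out higher numbers stand for weaker inhibition of growth and lower numbers for stronger inhibition of growth. Compound 1 gives 12200 nM in this assay. Compound 3 gives 30500 nM in this assay. For compound 2 this assay gives only a limit, > 100000 nM, which is the limit named in the limit of > 100000 nM in this assay, at which 1 of the 3 values shown sits.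

Compound 1 and compound 3 differ in one place, (methyl in place of ethoxy on a carbonyl carbon), and that step, a 2.5-fold higher number from compound 1 to compound 3 (0.40 log units; beyond the scatter), is modest but beyond the usual scatter. Compound 2 is built from the same atoms as compound 1, joined differently; the difference between the two cores is not broken down here.

Compound 4, `C=C(C)[C@@H]1CC=C(Cn2cc(COc3ccccc3C3NC(=O)NC(C)=C3C(C)=O)nn2)CC1`, has not yet been measured in this assay. It stands to compound 2 as compound 3 stands to compound 1: the change is methyl in place of ethoxy on a carbonyl carbon, the same change at the same kind of place. Because the measured step of a 2.5-fold higher number from compound 1 to compound 3 (0.40 log units; beyond the scatter) moved the number upward on the core of compound 1, the same direction is expected on the core of compound 2, as the step that the limit leaves unreadable from compound 2 to compound 4. Since compound 2 already sits at the limit of this assay, compound 4 is expected to sit there as well, and its estimated value is 250000 nM, with a range from 100000 nM to 700000 nM; most likely this assay will again report only a limit.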

Compound 4, concentration for total growth inhibition: 30200 nM
Compound 4: middle estimate off by 8.3-fold (0.92 log units), on the high side; measured number outside the range, below it.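

In this assay, the step of an at least 3.3-fold lower number from compound 2 to compound 4 (0.51 log units; beyond the scatter) runs the opposite way to the earlier step, a 2.5-fold higher number from compound 1 to compound 3 (0.40 log units; beyond the scatter), although both steps replace ethoxy with methyl on a carbonyl carbon whose other neighbour is a double-bonded ring carbon. The change from ethoxycarbonyl to acetyl therefore did not carry over from one core to the other in this pair of cores, and the disagreement is larger than repeated measurements would explain: the same change on two cores in this assay, a 2.5-fold higher number (0.40 log units; beyond the scatter) from compound 1 to compound 3 and an at least 3.3-fold lower number (0.51 log units; beyond the scatter) from compound 2 to compound 4, at least 8.2-fold (0.91 log units) apart, beyond the scatter of two such steps. For compound 2, > 100000 nM is a limit and not a number, so the step on that core has a known direction but no exact size, and these two pairs alone do not show why the cores part ways or how general the reversal is: the limit of > 100000 nM in this assay, at which 1 of the 4 values shown sits.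

The compounds shown leave open how a carboxylic acid, a primary amide or a longer ester chain such as propoxycarbonyl would behave in the same place on either core. They also leave open whether the change from ethoxycarbonyl to acetyl would go up or down on any further core.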